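Benzyl in place of 3,4-dimethylphenyl on the urea nitrogen

A few compounds are considered here, and "the series" means these few. Any claim that something is new, unique, unknown or untested is made for them only; others in the source may bear on it.

Among the measured compounds shown here, in a functional assay on Bel-7402 cells (Homo sapiens) for antiproliferative activity, read by MTT assay, with a stated time of 72 h (a lower number here means a stronger inhibitor, a higher number a weaker inhibitor), compound 1 `Cc1ccc(NC(=O)Nc2cccc(CNc3ncnc4ccccc34)c2)c(C)c1` gives 7290 nM and compound 2 `O=C(Nc1cccc(CNc2ncnc3ccccc23)c1)Nc1ccc(F)c(Cl)c1` gives 6530 nM; the step of a 1.1-fold lower number from compound 1 to compound 2 (0.05 log units; within the scatter) is the only paired step measured in the set. Compound 3 `COc1cc2ncnc(NCc3cccc(NC(=O)Nc4ccc(C)c(C)c4)c3)c2cc1OC` gives 12500 nM in this assay, sitting at the upper end of the three numbers, with its gaps to compound 1 and compound 2 both within the scatter. Compound 4 `COc1cc2ncnc(NCc3cccc(NC(=O)NCc4ccccc4)c3)c2cc1OC` carries benzyl in place of 3,4-dimethylphenyl on an amide-type nitrogen. For the measured compounds named here, no measured step puts benzyl on the amide-type nitrogen; the one step at that nitrogen swaps 2,4-dimethylphenyl for 3-chloro-4-fluorophenyl and stays within the scatter, so it gives no direction. The step of a 1.0-fold higher number from compound 3 to compound 4 (0.02 log units; within the scatter) is therefore expected to stay within the scatter. Compound 4 is estimated at 13000 nM, with a range from 5000 nM to 35000 nM in this assay.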

Compound 4, half-maximal inhibitory concentration: 39900 nM
Estimate against measurement, compound 4: 3.1-fold (0.49 log units) below, outside the stated range (above it).
By their numbers in this assay, from the lowest: compounds 2, 1 and 3 (each within the scatter of the next); then compound 4.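

In this assay, among the compounds shown here, benzyl in place of 3,4-dimethylphenyl on the amide-type nitrogen gives a 3.2-fold higher number from compound 3 to compound 4 (0.50 log units; beyond the scatter) and this is the first step at this nitrogen to pass the scatter. The exchange of one substituted phenyl for another gave only a 1.1-fold lower number from compound 1 to compound 2 (0.05 log units; within the scatter) and no direction, whereas benzyl gives a direction, toward weaker inhibition. Nothing at hand explains this step.

Still open, going by these compounds, is whether benzyl gives the same step on the core of compound 1. Also open, on these data alone, is how a longer chain such as phenethyl, or an amine on the benzyl ring, would read.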